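Methoxy in Place of Hydrogen on the Anilide Ring

The compounds below may be only part of what the source reports. "The series", "measured", "known", "first", "only" and "open" are said of these compounds alone.

Compound 2 `O=C(Nc1ccccc1)c1csc(Cc2c(Cl)cccc2Cl)n1` carries a plain phenyl ring on its amide. In an assay on CHO cells, read by calcium flux (on this read-out higher numbers stand for weaker inhibition and lower numbers for stronger inhibition), compound 2 gives only a limit, > 4000 nM. Compound 1 `CCc1ccc(NC(=O)c2csc(Cc3c(Cl)cccc3Cl)n2)cc1`, which bears an ethyl on that ring, gives 810 nM in this assay, so the step of an at least 4.9-fold higher number from compound 1 to compound 2 (0.69 log units; beyond the scatter) is a clear loss on removing the ethyl. Compound 3 `CN(C)c1ccc(NC(=O)c2csc(Cc3c(Cl)cccc3Cl)n2)cc1`, with a dimethylamino in that position, again reaches only a limit in this assay, > 4000 nM. Compound 4 `COc1ccc(NC(=O)c2csc(Cc3c(Cl)cccc3Cl)n2)cc1` differs from compound 2 by methoxy in place of hydrogen on an aromatic carbon. Ethyl gained, dimethylamino did not (an at least 4.9-fold higher number from compound 1 to compound 3 (0.69 log units; beyond the scatter)), and methoxy sits between them in kind, so a weak gain at most is expected. Compound 4 is expected near 3000 nM, within 800 nM to 10000 nM, a step of an at least 1.3-fold lower number from compound 2 to compound 4 (0.12 log units; that floor lies within the scatter) that may stay unreadable.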

Compound 4, half-maximal inhibitory concentration: > 4000 nM
Compound 4: no number, only a limit; the forecaster's own chance of this, stated with the estimate: 45%; middle value at least 1.3-fold (0.12 log units) away from the limit.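

Putting methoxy where ethyl stood gives an at least 4.9-fold higher number from compound 1 to compound 4 (0.69 log units; beyond the scatter). Ethyl is now the only group at this ring position with a readable value in this assay, since compound 2, compound 3 and compound 4 all stop at a limit. The steps among those three compounds therefore cannot be read: the limit of > 4000 nM in this assay, at which 3 of the 4 values shown sit.

From the compounds shown here alone, whether the gain is special to ethyl stays open, and a methyl or a propyl chain on the same carbon would test this. The limits also leave open how far compound 2, compound 3 and compound 4 truly lie apart.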